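Moving the amine out along a chain on the shared core

The compounds below may be only part of what the source reports. "The series", "measured", "known", "first", "only" and "open" are said of these compounds alone.

Compound 1, `c1ccc([C@H]2OC[C@H]([C@@H]3CCCCN3)O2)cc1`, gives 25000 nM in a functional assay (brain) for displacement of a labelled ligand, with Rattus norvegicus as the target; on this read-out higher numbers stand for weaker inhibition and lower numbers for stronger inhibition.
Compound 2, `CCCCCCCCC[C@]1(c2ccccc2)OC[C@H]([C@@H]2CCCCN2)O1`, gives 43000 nM.
Compound 3, `C[C@H](N)[C@H]1COC(c2ccccc2)(c2ccccc2)O1`, gives 607 nM.

Of the three measured compounds, compound 3 stands at the lowest number, so it is the strongest inhibitor in this set; its gaps to compound 1 and to compound 2 both lie well beyond the usual scatter, so this ranking is firm. Compound 1 and compound 2 sit far above it, with compound 2 the highest of the three.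

Compound 4, `CCNC[C@H]1COC(c2ccccc2)(c2ccccc2)O1`, has not been measured. It keeps the core of compound 3 with its two phenyl groups and differs in one place: (ethylamino)methyl in place of 1-aminoethyl on a saturated ring carbon. The amine-bearing side chain grows by one carbon, the nitrogen moves outward, and the defined stereocentre of compound 3 is lost.

Without a measured step of this kind in the set, the direction of the change cannot be read from the data. A step of modest size is expected, most likely toward a slightly higher number, as a 1.5-fold higher number from compound 3 to compound 4 (0.17 log units; within the scatter). Compound 4 is therefore expected to give 900 nM, within a range from 200 nM to 4000 nM.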

Compound 4, inhibition constant: 8400 nM
Compound 4: the middle estimate sits 9.3-fold (0.97 log units) below what was measured; measured number outside the range, above it.
By their numbers in this assay, from the lowest: compound 3; then compound 4; then compounds 1 and 2 (each within the scatter of the next).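

Going by these compounds alone, replacing 1-aminoethyl with (ethylamino)methyl on this saturated ring carbon, with the two phenyl groups left in place, gives the first one-place comparison in this set, and in this assay it produces a 14-fold higher number from compound 3 to compound 4 (1.14 log units; beyond the scatter). By the counts for the two groups, the entering group is only slightly larger, has the same hydrogen-bond donor and acceptor counts, and lacks the defined stereocentre of the group it replaces, so a modest edit at this position can shift the read-out strongly toward weaker inhibition. Nothing measured here accounts for the size of this shift.

Within the data shown here, the single step changes several features together, so it remains open whether the loss follows the ethyl group on the nitrogen, the outward move of the nitrogen or the missing stereocentre, and a 2-aminoethyl chain or a plain aminomethyl group on the same ring carbon would help separate these. Among these compounds, compound 1 and compound 2 differ from compound 3 in more than one place, so they offer no step to set beside this one.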